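This account rests on a few compounds, and the source may have more. Where it says the series, first, only, none or still open, it means among the compounds named here.

In a functional assay on SGC-7901 cells (Homo sapiens) for cytotoxicity, read by MTT assay, with a stated time of 48 h (on this read-out higher numbers stand for weaker inhibition and lower numbers for stronger inhibition), three compounds sharing one core have been measured. Compound 1 `Cc1ncc([N+](=O)[O-])n1CCSc1nnc(-c2ccccc2F)o1` gives 33700 nM, compound 2 `Cc1ncc([N+](=O)[O-])n1CCSc1nnc(-c2ccc(F)cc2)o1` gives 5300 nM, and compound 3 `Cc1ncc([N+](=O)[O-])n1CCSc1nnc(-c2ccco2)o1` gives 31700 nM. Compound 3 therefore stands level with compound 1, with a gap of a 1.1-fold lower number from compound 1 to compound 3 (0.03 log units; within the scatter), and it stands clearly above compound 2, with a 6.0-fold higher number from compound 2 to compound 3 (0.78 log units; beyond the scatter).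

The next molecule, compound 4 `Cc1ncc([N+](=O)[O-])n1CCSc1nnc(-c2ccc(N)nc2)o1`, has 6-aminopyridin-3-yl in place of furan-2-yl on an aromatic carbon. For the measured compounds named here, no measured compound carries this new group, so the evidence is indirect. Replacing the furan-2-yl group with a six-membered aromatic ring has gone both ways. The ring in compound 2 gave the modest 6.0-fold higher number from compound 2 to compound 3 (0.78 log units; beyond the scatter), whereas the ring in compound 1 gave no change beyond the scatter. The fluorine shift alone gave a 6.4-fold lower number from compound 1 to compound 2 (0.80 log units; beyond the scatter), so the substitution pattern on such a ring can matter as much as the ring itself. A modest drop in this assay therefore seems likely, though smaller than the full gap between compound 2 and compound 3. The expected change is a 2.3-fold lower number from compound 3 to compound 4 (0.35 log units; beyond the scatter). For compound 4, the estimated value is 14000 nM, with an expected range of 4000 nM to 45000 nM.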

Compound 4, half-maximal inhibitory concentration: 30900 nM
The estimate for compound 4 lay 2.2-fold (0.34 log units) below the measured number; the range from low to high includes it.
By their numbers in this assay, from the lowest: compound 2; then compounds 4, 3 and 1 (each within the scatter of the next).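

In this assay, putting 6-aminopyridin-3-yl on this carbon of the shared core changes nothing beyond the scatter, whether it replaces furan-2-yl (a 1.0-fold lower number from compound 3 to compound 4 (0.01 log units; within the scatter)) or 2-fluorophenyl (a 1.1-fold lower number from compound 1 to compound 4 (0.04 log units; within the scatter)). A six-membered aromatic ring with a hydrogen-bond donor therefore does not reach the level of the 4-fluorophenyl group (a 5.8-fold higher number from compound 2 to compound 4 (0.77 log units; beyond the scatter)), so compound 2 alone stands apart, with the lowest number of the four, while three quite different groups sit level. Nothing measured here explains what sets the 4-fluorophenyl group apart.

A plain phenyl or a 4-chlorophenyl group at this carbon would help show whether the fluorine itself matters or only a group in that position on the ring. A pyridin-3-yl group without the amine would show what the amine contributes.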